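The compounds below may be only part of what the source reports. "The series", "measured", "known", "first", "only" and "open" are said of these compounds alone.

Compound 1 `CC(C)c1c(C(=O)N(C)Cc2ccccc2)nn(-c2ccc(F)cc2)c1OC[C@@H](O)C[C@@H](O)CC(=O)O` in an assay on microsomes from liver for inhibition of 3-hydroxy-3-methylglutaryl-coenzyme A reductase (Rattus norvegicus) (a higher number here means a weaker inhibitor, a lower number a stronger inhibitor), gives 5.2 nM. Compound 2 `COc1cccc(CNC(=O)c2nn(-c3ccc(F)cc3)c(OC[C@@H](O)C[C@@H](O)CC(=O)O)c2C(C)C)c1` in this assay gives 16 nM.

Within the data shown here, of these two numbers compound 2 has the higher one, so it is the weaker inhibitor of the pair; the only measured step, a 3.1-fold higher number from compound 1 to compound 2 (0.49 log units; beyond the scatter), separates it from compound 1 and is modest but beyond the scatter. Compound 3 `COc1ccccc1CNC(=O)c1nn(-c2ccc(F)cc2)c(OC[C@@H](O)C[C@@H](O)CC(=O)O)c1C(C)C` is built from the same atoms as compound 2, joined differently: 2-methoxyphenyl in place of 3-methoxyphenyl on a saturated chain carbon bound to an amide-type nitrogen. Among the measured compounds shown here, no measured step exchanges 3-methoxyphenyl for 2-methoxyphenyl, and the step of a 3.1-fold higher number from compound 1 to compound 2 (0.49 log units; beyond the scatter) concerns a different part of the amide substituent, so it offers no direct guide. With nothing that bears on this change, the expectation is a step within the scatter in this assay. Compound 3 is therefore estimated at 20 nM, with a range from 7 nM to 60 nM, which means an expected step of a 1.3-fold higher number from compound 2 to compound 3 (0.10 log units; within the scatter).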

Compound 3, half-maximal inhibitory concentration: 22 nM
Compound 3: the middle estimate sits 1.1-fold (0.04 log units) below what was measured; low and high end bracket the measured number.
By their numbers in this assay, from the lowest: compound 1; then compounds 2 and 3 (each within the scatter of the next).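

In this assay, 2-methoxyphenyl in place of 3-methoxyphenyl gives a 1.4-fold higher number from compound 2 to compound 3 (0.14 log units; within the scatter), so at this place on the amide substituent, the two arrangements of the methoxyphenyl group cannot be told apart. The (2-methoxybenzyl)amino group also gives a 4.2-fold higher number from compound 1 to compound 3 (0.63 log units; beyond the scatter), which shows that the separation from the benzyl(methyl)amino group seen in a 3.1-fold higher number from compound 1 to compound 2 (0.49 log units; beyond the scatter) holds for both methoxy compounds. No supporting measurement offers an explanation for either step.

Compounds 2 and 3 each differ from compound 1 in two features, a methoxy group on the ring and a hydrogen in place of the methyl on the amide nitrogen, and the compounds shown do not separate these two features. From the compounds shown here alone, a plain benzylamino group would be needed to do that, and where it would fall in this assay remains open.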